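The source may hold more compounds than are shown below. What is called first, only, known or untested is meant among the compounds shown, and "the series" means these compounds.

Working notes on the series in an ADME assay on A549 cells (Homo sapiens) for cytotoxicity, read by resazurin assay, with a stated time of 48 h; on this read-out higher numbers stand for lower toxicity in this test and lower numbers for higher toxicity in this test. Compound 1 `CC1(Nc2ccc(NC(=O)c3cc(Cl)ccc3O)c(Cl)c2)CCCC1` gives 157000 nM, the highest of the three numbers. Compound 2 `CCCN(CCC)c1ccc(NC(=O)c2cc(Cl)ccc2O)c(Cl)c1` gives 10700 nM and compound 3 `O=C(Nc1ccc(NCc2cc(F)cc(Cl)c2)cc1Cl)c1cc(Cl)ccc1O` gives 11100 nM, two values within the scatter of each other. Compound 3 therefore shares the low end of the series with compound 2.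

Compound 4 `CC(C)(CCO)Nc1ccc(NC(=O)c2cc(Cl)ccc2O)c(Cl)c1` is the next case: 3-hydroxy-1,1-dimethylpropyl in place of 3-chloro-5-fluorobenzyl on a nitrogen on an aromatic ring.

Among the measured compounds shown here, two measured steps bear on this change, and both are large: a 14-fold lower number from compound 1 to compound 3 (1.15 log units; beyond the scatter) and a 15-fold lower number from compound 1 to compound 2 (1.17 log units; beyond the scatter). The first is the more relevant, since it concerns the same nitrogen and the same 3-chloro-5-fluorobenzyl group. Compound 4 gives up that benzyl group for a branched chain that is closer in shape to the 1-methylcyclopentyl of compound 1, so a move towards higher numbers is expected. Compound 2 argues against a full return: it has no aromatic ring in its dipropylamino group, yet it stays at 10700 nM. For the measured compounds named here, no measured compound carries a hydroxy group on this chain, so that part of the change is untested.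

A sizeable rise is expected in this assay, stopping short of compound 1. The expected step is a 5.4-fold higher number from compound 3 to compound 4 (0.73 log units; beyond the scatter). Compound 4 is estimated at 60000 nM, with an expected range of 20000 nM to 180000 nM.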

Compound 4, half-maximal cytotoxic concentration: 170000 nM
For compound 4 the middle estimate is 2.8-fold (0.45 log units) below the measured one, within the range that was stated.
By their numbers in this assay, from the lowest: compounds 2 and 3 (each within the scatter of the next); then compounds 1 and 4 (each within the scatter of the next).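

In this assay, 3-hydroxy-1,1-dimethylpropyl in place of 3-chloro-5-fluorobenzyl on this nitrogen gives a large step (a 15-fold higher number from compound 3 to compound 4 (1.19 log units; beyond the scatter)), and the same group set against dipropylamino gives one of similar size (a 16-fold higher number from compound 2 to compound 4 (1.20 log units; beyond the scatter)), so a group with no ring can stand at the high end of the series, which compound 2 alone gave no sign of. The hydroxy chain and the 1-methylcyclopentyl group cannot be told apart (a 1.1-fold higher number from compound 1 to compound 4 (0.03 log units; within the scatter)), and among these four compounds the two branched groups share the high end while 3-chloro-5-fluorobenzyl and dipropylamino share the low end. Nothing measured here accounts for this split.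

Which part of the new chain carries the result stays open, since its branching and its hydroxy group change together in this comparison. An unbranched 3-hydroxypropyl group, a 1,1-dimethylpropyl group without the hydroxy group, and a longer chain ending in an amine or a carboxylic acid would separate these features on this nitrogen.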